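The compounds below may be only part of what the source reports. "The series", "measured", "known", "first", "only" and "open" are said of these compounds alone.

Among the measured compounds shown here, compound 1 `Cc1ccc(OCc2ccccc2-c2nc(-c3cc(Cl)sc3S(N)(=O)=O)cs2)cc1` is one of three compounds measured in a functional assay on the whole organism (strain Wistar albino) for inhibition, with Rattus norvegicus as the target, read by paw edema, at a dose of 10 mg/kg by the oral route (on this read-out lower numbers stand for less inhibition and higher numbers for more inhibition at the one dose given (going by the name of the read-out)), where compound 1 gives 68.7%. Compound 2 `Cc1ccc(OCc2ccccc2-c2nc(COc3ccc(Cl)cc3)cs2)cc1` gives 68.7% in this assay, and compound 3 `Cc1ccc(OCc2ccccc2-c2nc(-c3cccc(Br)c3)cs2)cc1` gives 44.5%. Compound 1 stands level with compound 2, the two together at the top of the three numbers, with compound 3 the furthest away.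

The measured steps all change the group on an aromatic carbon of the shared core: no change at the digits printed from compound 1 to compound 2 (within the scatter), a number 24.2 percentage points lower from compound 1 to compound 3 (beyond the scatter), and a number 24.2 percentage points lower from compound 2 to compound 3 (beyond the scatter).

Compound 4 `Cc1cccc(OCc2ccccc2-c2nc(-c3cc(Cl)sc3S(N)(=O)=O)cs2)c1` differs from compound 1 in another part of the molecule: 3-methylphenyl in place of 4-methylphenyl on an oxygen on a saturated carbon. For the measured compounds named here, no measured step touches this part of the molecule, so none of the three steps bears directly on it; they show only that swapping the group on the aromatic carbon can shift the number by a modest amount or not at all. With the same atoms joined differently and the rest of compound 1 kept, the expected outcome is no step beyond the scatter, a number 3.7 percentage points lower from compound 1 to compound 4 (within the scatter). Compound 4 is therefore estimated to give 65% in this assay, expected to fall between 50% and 78%.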

Compound 4, a percentage reported as inhibition, in the whole organism at one dose (the size of the read-out at that dose, not a potency): 66.8%
The estimate for compound 4 lay 1.8 percentage points below the measured number; the measured number falls inside the stated range.
By their numbers in this assay, from the lowest: compound 3; then compounds 4, 1 and 2 (each within the scatter of the next).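

Among the compounds shown here, compound 4 gives the first reading on the far end of the molecule, since every earlier step changed only the group on an aromatic carbon of the shared core. In this assay, 3-methylphenyl in place of 4-methylphenyl on an oxygen on a saturated carbon gives a number 1.9 percentage points lower from compound 1 to compound 4 (within the scatter), so at this one dose the two compounds cannot be told apart, at least with the rest of compound 1 kept. Nothing available here offers an explanation for this result.

The compounds shown all keep a methylphenyl group on this oxygen, so they leave open whether the methyl itself matters; a plain phenyl, a methoxyphenyl or a chlorophenyl group there would begin to answer that. A reading at a single dose gives the size of the effect and not a potency, so compound 1 and compound 4 could still part ways at other doses, and the same swap might also read differently on a core carrying the 3-bromophenyl group of compound 3.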